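Swapping a hydroxymethyl for an isobutyl on the oxadiazole

The source may report more compounds than this note shows. Statements on the series, on what has been measured and on what is new or still open speak of the compounds shown alone.

Three compounds share one core and differ only in the small ring at one end. In an assay on microsomes from liver for inhibition of acyl-CoA desaturase 1 (Rattus norvegicus) (a lower number here means a stronger inhibitor, a higher number a weaker inhibitor), compound 1 `CC(C)c1nnc(-c2ccc(N3CCC(Oc4ccccc4C(F)(F)F)CC3)nn2)s1` gives 8.8 nM, compound 2 `CC(C)(C)c1nnc(-c2ccc(N3CCC(Oc4ccccc4C(F)(F)F)CC3)nn2)o1` gives 980 nM, and compound 3 `OCc1nnc(-c2ccc(N3CCC(Oc4ccccc4C(F)(F)F)CC3)nn2)o1` gives 2.9 nM. Compound 3 has the lowest number of the three, with the step of a 3.0-fold lower number from compound 1 to compound 3 (0.48 log units; beyond the scatter) and the step of a 340-fold lower number from compound 2 to compound 3 (2.53 log units; beyond the scatter) both pointing toward it. Compound 4 `CC(C)Cc1nnc(-c2ccc(N3CCC(Oc4ccccc4C(F)(F)F)CC3)nn2)o1` is built from compound 3 by a single change: isopropyl in place of hydroxy on a saturated chain carbon bound to an aromatic carbon. Among the measured compounds shown here, two measured steps bear on this. The step of a 340-fold lower number from compound 2 to compound 3 (2.53 log units; beyond the scatter) shows that a branched alkyl group on this ring carries a very much higher number than hydroxymethyl does, while the step of a 3.0-fold lower number from compound 1 to compound 3 (0.48 log units; beyond the scatter) shows that an isopropyl group on a related ring sits only modestly above compound 3. Isobutyl is a branched alkyl group, so a higher number is expected for compound 4, likely somewhere between those two outcomes, giving an expected step of a 34-fold higher number from compound 3 to compound 4 (1.54 log units; beyond the scatter) in this assay. The estimate for compound 4 is 100 nM, expected to lie between 15 nM and 600 nM.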

Compound 4, half-maximal inhibitory concentration: 15 nM
Compound 4: middle estimate off by 6.7-fold (0.82 log units), on the high side, and the stated range covers the measured number.
By their numbers in this assay, from the lowest: compound 3; then compounds 1 and 4 (each within the scatter of the next); then compound 2.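

In this assay, the hydroxy group of hydroxymethyl on the oxadiazole can give way to an all-carbon chain at only a modest cost (a 5.2-fold higher number from compound 3 to compound 4 (0.71 log units; beyond the scatter)). Alkyl groups at this position are not interchangeable, since replacing tert-butyl with isobutyl has a large effect (a 65-fold lower number from compound 2 to compound 4 (1.82 log units; beyond the scatter)), so a low number depends on which alkyl group is present, not merely on having one. The 5-isobutyl-1,3,4-oxadiazol-2-yl and 5-isopropyl-1,3,4-thiadiazol-2-yl end groups cannot be told apart (a 1.7-fold higher number from compound 1 to compound 4 (0.23 log units; within the scatter)).

Nothing available here explains these differences. Going by these compounds, it remains open how a longer unbranched chain such as n-butyl, or an amine such as aminomethyl, would behave on the same ring.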